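The source may report more compounds than this note shows. Statements on the series, on what has been measured and on what is new or still open speak of the compounds shown alone.

Among the compounds with values here, the study follows a shared core, the one of compound 3 `CC1(C)OC(C)(C)c2nc(-c3ccccc3)nnc21`, whose aryl ring carries groups that differ from compound to compound. In a functional assay on the whole organism with Mus musculus as the target (on this read-out lower numbers stand for an effect already at smaller amounts and higher numbers for an effect only at larger amounts of compound), compound 3 gives 167 mg/kg, the second highest of the three numbers recorded so far. Compound 1 `Cc1cccc(-c2nnc3c([n+]2[O-])C(C)(C)OC3(C)C)c1` gives 150 mg/kg, a number that lies within the scatter of compound 3, while compound 2 `CC1(C)OC(C)(C)c2c1nnc(-c1ccc(F)cc1)[n+]2[O-]` gives 500 mg/kg. Within the data shown here, the one step measured on this ring, a 3.3-fold higher number from compound 1 to compound 2 (0.52 log units; beyond the scatter), shows that a change of the aryl substituent can shift the read-out modestly. Compound 4 `CC1(C)OC(C)(C)c2nc(-c3cccc([N+](=O)[O-])c3)nnc21` differs from compound 3 by nitro in place of hydrogen on an aromatic carbon. Among the measured compounds shown here, no measured step introduces a nitro group, so the expectation rests on the narrow spread of compounds 1 and 3: compound 4 is estimated at 200 mg/kg, in the range 80 mg/kg to 500 mg/kg, which means an expected step of a 1.2-fold higher number from compound 3 to compound 4 (0.08 log units; within the scatter).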

Compound 4, dose for half-maximal effect: 68.8 mg/kg
Beside the measured number, compound 4's estimate is 2.9-fold (0.46 log units) above it; the measured number lies below the stated range.
By their numbers in this assay, from the lowest: compound 4; then compounds 1 and 3 (each within the scatter of the next); then compound 2.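

In this assay, within the data shown here, nitro in place of hydrogen, meta to a large group, brings a 2.4-fold lower number from compound 3 to compound 4 (0.39 log units; beyond the scatter), the first measured change on this aryl ring that lowers the number. The earlier step on the ring went the other way, so substituent changes here can move the number in either direction. Nothing available bears on why the number falls. The compounds shown leave open whether the lower number belongs to nitro itself or to any substitution at this place on the ring, and how an amine or a methoxy group there would compare.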